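Swapping the charged ring end in a collagen promoter series

The source may report more compounds than this note shows. Statements on the series, on what has been measured and on what is new or still open speak of the compounds shown alone.

Measured compounds:
- compound 1 `Cc1cc(OCCCCCCC[N+]23CCN(CC2)CC3)ccc1-n1cc(C(=O)Nc2cc(F)cc(F)c2)c(=O)c2ccc(N(C)C)nc21`: "not active" (no number reported)
- compound 2 `Cc1cc(-n2cc(C(=O)Nc3cc(F)cc(F)c3)c(=O)c3ccc(N(C)C)nc32)ccc1OCCCCCCC[N+]1(C)CCCC1`: 35.9%
- compound 3 `CN(C)c1ccc2c(=O)c(C(=O)Nc3cc(F)cc(F)c3)cn(-c3ccc(OCCCCCCC[N+]4(C)CCCC4)c(Cl)c3)c2n1`: 2.59%

In an assay on LX2 cells for inhibition of COL1A1 promoter (Homo sapiens), read by a luciferase reporter, with a stated time of 24 h, tested at 50 uM (on this read-out lower numbers stand for a weaker effect and higher numbers for a stronger effect at the one concentration tested), compound 2 gives 35.9%, while compound 1 is reported only as "not active" (no number reported) with no number. Among the compounds with values here, compound 3 gives 2.59%, the lowest of the two numbers available; its nearest neighbour is compound 2, and the single step recorded, a number 33.3 percentage points lower from compound 2 to compound 3 (beyond the scatter), is the only measured change in this set.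

Compound 4 `CN(C)c1ccc2c(=O)c(C(=O)Nc3cc(F)cc(F)c3)cn(-c3ccc(OCCCCCCC[n+]4ccccc4)c(Cl)c3)c2n1` differs from compound 3 in one place: a group of 6 heavy atoms (5 carbon, 1 nitrogen; one six-membered aromatic ring with 1 hetero atom) in place of a group of 6 heavy atoms (5 carbon, 1 nitrogen; one five-membered non-aromatic ring with 1 hetero atom), on a saturated chain carbon, seven bonds along the chain from an oxygen on an aromatic ring. Within the data shown here, no measured step touches the charged end of the chain, since the one recorded step concerns a substituent on the aromatic ring instead. There is therefore nothing in the data to say which way this change should move the read-out, and the cautious expectation is no step beyond the scatter.

For compound 4 in this assay the expected value is 5%, within a range from -8% to 25%, which corresponds to an expected step of a number 2.4 percentage points higher from compound 3 to compound 4 (within the scatter).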

Compound 4, a percentage reported as inhibition, at one concentration (the size of the read-out at that concentration, not a potency): 21.4%
Estimate against measurement, compound 4: 16.4 percentage points below; measured number inside the range.
By their numbers in this assay, from the lowest: compound 3; then compound 4; then compound 2.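

In this assay, the charged ring at the end of the chain proves to be a position that matters: a six-membered aromatic ring with 1 hetero atom in place of a five-membered non-aromatic ring with 1 hetero atom gives a number 18.8 percentage points higher from compound 3 to compound 4 (beyond the scatter). The two groups match in heavy atoms, net charge and hydrogen-bond counts, so the read-out can shift with the ring alone, even when everything else on the molecule stays the same. Nothing measured here explains the shift.

Ring size and aromatic character change together in this swap, so a six-membered non-aromatic ring with one nitrogen would be needed to tell them apart. From the compounds shown here alone, it also remains open whether the same six-membered aromatic ring would give a similar step with methyl in place of chloro on the aromatic carbon.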